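The source may report more compounds than this note shows. Statements on the series, on what has been measured and on what is new or still open speak of the compounds shown alone.

Compound 1 `CC(=O)N1N=C(c2ccc3ccccc3c2)OC1c1ccccc1Br` gives 3.98 ug/mL in a functional assay on HepG2 cells (Homo sapiens) for antiproliferative activity, read by MTT assay, with a stated time of 48 h (a lower number here means a stronger inhibitor, a higher number a weaker inhibitor), the lowest of the two numbers in hand. Compound 2 `CC(=O)N1N=C(c2ccc3ccccc3c2)OC1c1ccccc1[N+](=O)[O-]` gives 12.3 ug/mL in this assay, a step described as a 3.1-fold higher number from compound 1 to compound 2 (0.49 log units; beyond the scatter).

Compound 3 `CC(=O)N1N=C(c2ccc3ccccc3c2)OC1c1ccsc1` differs from compound 1 by thiophen-3-yl in place of 2-bromophenyl on a saturated ring carbon. For the measured compounds named here, no measured step concerns this change: the single step on record swaps one group for another on the 2-bromophenyl ring, whereas here the whole 2-bromophenyl ring leaves and thiophen-3-yl enters. That step at least shows that changes at this site can move the number beyond the scatter, but its direction and size give no direct guide. The working expectation is a modest rise or no change beyond the scatter, with wide uncertainty. Compound 3 is therefore estimated at 6 ug/mL, with a range from 2.5 ug/mL to 15 ug/mL. The step this estimate implies is a 1.5-fold higher number from compound 1 to compound 3 (0.18 log units; within the scatter).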

Compound 3, half-maximal inhibitory concentration: 6.82 ug/mL
Beside the measured number, compound 3's estimate is 1.1-fold (0.06 log units) below it; the measured number falls inside the stated range.
By their numbers in this assay, from the lowest: compounds 1, 3 and 2 (each within the scatter of the next, the first and the last beyond it).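

In this assay, thiophen-3-yl in place of 2-bromophenyl on the saturated ring carbon gives a 1.7-fold higher number from compound 1 to compound 3 (0.23 log units; within the scatter), and the same group in place of 2-nitrophenyl gives a 1.8-fold lower number from compound 2 to compound 3 (0.26 log units; within the scatter). This position therefore accepts a five-membered aromatic ring with 1 hetero atom in place of either six-membered aromatic ring with no step beyond the scatter, even though compound 1 and compound 2 stand beyond the scatter of each other. No measurement at hand bears on why this exchange gives such a result.

Open, going by these compounds, is whether unsubstituted phenyl, thiophen-2-yl or a saturated group such as cyclohexyl on this carbon would stay within the scatter of compound 3. Also open, on these data alone, is what an amine or a carboxylic acid on that ring, or propanoyl in place of the acetyl group, would do to the number.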